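Oxazolidinone ether series: aryl to hydroxycyclohexyl swap

The compounds below may be only part of what the source reports. "The series", "measured", "known", "first", "only" and "open" are said of these compounds alone.

The series is read in an assay on HEK293 cells for inhibition of N-acylethanolamine-hydrolyzing acid amidase (Rattus norvegicus), read by LC-MS, with a stated time of 30 min; a higher number here means a weaker inhibitor, a lower number a stronger inhibitor. Compound 1 `O=C(O)c1cccc(CCCCCC(=O)N2CCOC2=O)c1` is recorded there only as a limit of the assay, > 20000 nM. Compound 2 `O=C1OCCN1C(=O)c1ccc(Oc2cccc(Cl)c2)cc1` gives 7740 nM in this assay, the only actual number shown for the series. The value of compound 1 is a limit, as noted in the limit of > 20000 nM in this assay, at which 1 of the 2 values shown sits. Compound 2 is thus the reference point for the next step.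

Compound 3 `O=C1OCCN1C(=O)c1ccc(OC2CCC(O)CC2)cc1` is still to be measured. It differs from compound 2 in one place: 4-hydroxycyclohexyl in place of 3-chlorophenyl on an oxygen on an aromatic ring. Within the data shown here, no step between two measured compounds is available, and the effect of 4-hydroxycyclohexyl in place of 3-chlorophenyl on an oxygen on an aromatic ring has no measured counterpart. The expected change in this assay is a 1.8-fold higher number from compound 2 to compound 3 (0.26 log units; within the scatter), a loss beyond the usual scatter. Compound 3 is estimated at 14000 nM, with a range from 4000 nM to 50000 nM.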

Compound 3, half-maximal inhibitory concentration: 210 nM
For compound 3 the middle estimate is 67-fold (1.82 log units) above the measured one; measured number outside the range, below it.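

With 4-hydroxycyclohexyl in place of 3-chlorophenyl on an oxygen on an aromatic ring, this assay shows a 37-fold lower number from compound 2 to compound 3 (1.57 log units; beyond the scatter) and thereby marks this position as one that strongly affects the read-out, which compound 1 and compound 2 alone could not show. The two groups each hold 7 heavy atoms, so heavy-atom count does not separate them; the change instead replaces an aromatic carbon ring bearing chlorine with a non-aromatic carbon ring bearing a hydrogen-bond donor and acceptor. No measurement shown accounts for this large step.

On these data alone, it remains open whether the hydroxyl or the loss of the aromatic ring carries the step. A plain cyclohexyl and a 4-aminocyclohexyl on the same oxygen would help to separate these two changes.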